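A Methyl for a Fluoro in Compound 4

A few compounds are considered here, and "the series" means these few. Any claim that something is new, unique, unknown or untested is made for them only; others in the source may bear on it.

Three compounds share one core and differ only in the phenyl group on a sulfonamide nitrogen. In a functional assay on cells (leukaemia cell line, Homo sapiens) for inhibition, read by sulforhodamine B assay, with a stated time of 48 h (on this read-out higher numbers stand for weaker inhibition of growth and lower numbers for stronger inhibition of growth), compound 1 `O=S(=O)(Nc1ccc(F)c(Cl)c1)c1ccc(-c2cnc(C3CC3)o2)cc1` gives 260 nM and compound 2 `O=S(=O)(Nc1ccc(F)cc1F)c1ccc(-c2cnc(C3CC3)o2)cc1` gives 356 nM as its number. The change between them is a 1.4-fold higher number from compound 1 to compound 2 (0.14 log units; within the scatter) and counts as no real difference. Compound 3 `O=S(=O)(Nc1cc(F)cc(Cl)c1)c1ccc(-c2cnc(C3CC3)o2)cc1` gives 1440 nM as the highest number of the three, which makes it the weakest growth inhibitor here. The steps behind that ranking are a 5.5-fold higher number from compound 1 to compound 3 (0.74 log units; beyond the scatter) and a 4.0-fold higher number from compound 2 to compound 3 (0.61 log units; beyond the scatter) and both are modest.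

Compound 4 `Cc1cc(Cl)cc(NS(=O)(=O)c2ccc(-c3cnc(C4CC4)o3)cc2)c1` has not been measured. It keeps the core and the chloro group but carries methyl in place of fluoro on an aromatic carbon. For the measured compounds named here, no measured step makes this swap, so the evidence is indirect. Going by the values given here, the three steps above show only that changes to this phenyl group have ranged from nothing detectable to modest. A step beyond the scatter in either direction cannot be excluded, but none is expected in this assay on these data. The expected step is a 1.1-fold lower number from compound 3 to compound 4 (0.04 log units; within the scatter) and this remains a rough expectation. Compound 4 is estimated at 1300 nM (expected range 500 nM to 3300 nM).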

Compound 4, concentration for 50% growth inhibition: 175 nM
Estimate against measurement, compound 4: 7.4-fold (0.87 log units) above, outside the stated range (below it).
By their numbers in this assay, from the lowest: compounds 4, 1 and 2 (each within the scatter of the next, the first and the last beyond it); then compound 3.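

For the compounds shown here, on an aromatic carbon meta to a chloro group, methyl in place of fluoro gives an 8.2-fold lower number from compound 3 to compound 4 (0.92 log units; beyond the scatter) in this assay, so this single group matters more here than any change among the earlier compounds had suggested. The earlier data could have been read as saying that the 3-chloro-5-fluorophenyl arrangement itself was poor, yet 3-chloro-5-methylphenyl keeps the chloro group at the same place and the result is a 2.0-fold lower number from compound 2 to compound 4 (0.31 log units; beyond the scatter), while a 1.5-fold lower number from compound 1 to compound 4 (0.17 log units; within the scatter) shows no real difference, which places compound 4 among the better compounds rather than with compound 3. Nothing measured in this set explains why the swap has so large an effect on growth inhibition.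

On these data alone, whether ethyl, methoxy, trifluoromethyl or an amine at this place would match methyl or fall back towards fluoro remains open, so methyl cannot yet be called the best group here. As far as these compounds go, it is also open whether the gain depends on the chloro group, which a compound carrying bromo or a second methyl in its place would help to show.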